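The source may hold more compounds than are shown below. What is called first, only, known or untested is meant among the compounds shown, and "the series" means these compounds.

Measured in a functional assay on A549 cells (Homo sapiens) for inhibition, read by MTT assay, with a stated time of 72 h; on this read-out higher numbers stand for weaker inhibition and lower numbers for stronger inhibition:
- compound 1 `COc1cc(OC)c(OC)cc1/C=C/C(=O)c1c(OC)cc(O)c(CC=C(C)C)c1O`: 14400 nM
- compound 2 `COc1cc(O)c(CC=C(C)C)c(O)c1C(=O)/C=C/c1cccc([N+](=O)[O-])c1`: 15000 nM
- compound 3 `COc1ccc(/C=C/C(=O)c2c(O)cc(O)cc2OC)cc1`: > 50000 nM

Compound 1 gives 14400 nM, and compound 2 gives 15000 nM, so these two numbers lie within the usual scatter of each other. Both compounds carry a 3-methylbut-2-en-1-yl group.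

Compound 4 `COc1cc(OC)c(OC)cc1/C=C/C(=O)c1c(O)cc(O)cc1OC` has not yet been measured. It differs from compound 1 by one change, hydrogen in place of 3-methylbut-2-en-1-yl on an aromatic carbon, ortho to two hydroxy groups.

Compound 3, which also has no 3-methylbut-2-en-1-yl group, stands at > 50000 nM, a limit of the assay and not a number. Among the compounds with values here, this single compound is the only guide to the change, so the expectation is uncertain. In this assay the expected step is a 2.8-fold higher number from compound 1 to compound 4 (0.44 log units; beyond the scatter), towards weaker inhibition, and a report of only a limit is quite possible. For compound 4 the estimate is 40000 nM, with an expected range from 20000 nM to 80000 nM.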

Compound 4, half-maximal inhibitory concentration: 34200 nM
Estimate against measurement, compound 4: 1.2-fold (0.07 log units) above; the range from low to high includes it.
By their numbers in this assay, from the lowest: compounds 1 and 2 (each within the scatter of the next); then compound 4. At a limit, above all of these: compound 3.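

In this assay, within the data shown here, swapping the 3-methylbut-2-en-1-yl group for hydrogen gives a 2.4-fold higher number from compound 1 to compound 4 (0.38 log units; beyond the scatter), a modest move towards weaker inhibition and the first direct reading of this position. On the core of compound 1, the group on this aromatic carbon, ortho to two hydroxy groups, therefore adds to inhibition, but inhibition remains measurable without it. Compound 3 alone sits at a limit, which is not a number, and compound 4 does not: the limit of > 50000 nM in this assay, at which 1 of the 4 values shown sits.

The compounds shown compare only hydrogen and 3-methylbut-2-en-1-yl at this position, so it remains open how a methyl group, a 3-methylbutyl chain without the double bond, or an amine would fare there. This single pair also leaves open whether the same step would appear on the core of compound 2.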